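From Cyclohexyl to Cyclopentyloxy on a Carbonyl Carbon

The source may report more compounds than this note shows. Statements on the series, on what has been measured and on what is new or still open speak of the compounds shown alone.

Three compounds sharing one core were examined in a functional assay on HepG2 cells (Homo sapiens) for inhibition, read by scintillation counting, with a stated time of 2 h; on this read-out lower numbers stand for stronger inhibition and higher numbers for weaker inhibition: compound 1 (`CCNC(=O)Nc1sc2ccccc2c1C(=O)N1CCN(C2CCN(C(=O)C3CCN(C(C)=O)CC3)CC2)CC1`), compound 2 (`CCCCC(=O)N1CCC(N2CCN(C(=O)c3c(NC(=O)NCC)sc4ccccc34)CC2)CC1`) and compound 3 (`CCNC(=O)Nc1sc2ccccc2c1C(=O)N1CCN(C2CCN(C(=O)C3CCCCC3)CC2)CC1`). Compound 1 is recorded as "not determined" (no result reported). Compound 2 is recorded as "not determined" (no result reported). Going by the values given here, only compound 3 has a number, 146 nM, so it stands alone, with no other measured compound to rank it against.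

Compound 4 (`CCNC(=O)Nc1sc2ccccc2c1C(=O)N1CCN(C2CCN(C(=O)OC3CCCC3)CC2)CC1`) has yet to be measured in this assay. It carries cyclopentyloxy in place of cyclohexyl on a carbonyl carbon. Among the compounds with values here, no measured pair of compounds shows how this assay responds to a change of this kind, so the expectation rests on compound 3 at 146 nM alone. With no evidence favouring either direction, the expected change is a 1.1-fold lower number from compound 3 to compound 4 (0.05 log units; within the scatter), a step no larger than the usual scatter. For compound 4 the estimated value is 130 nM, with an expected range of 35 nM to 480 nM.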

Compound 4, half-maximal inhibitory concentration: 512 nM
The estimate for compound 4 lay 3.9-fold (0.60 log units) below the measured number; measured number above the stated range.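

In this assay, going by these compounds alone, replacing cyclohexyl with cyclopentyloxy on a carbonyl carbon gives a 3.5-fold higher number from compound 3 to compound 4 (0.54 log units; beyond the scatter), the only measured reading of how this position responds. It shows that this place is sensitive to the group on the carbonyl carbon, even though the number of heavy atoms stays the same while an oxygen enters and a five-membered ring replaces a six-membered one. Nothing available explains the higher number.

The change alters the oxygen and the ring size together, so the compounds shown cannot separate the two; cyclopentyl or cyclohexyloxy on the same carbonyl carbon would be needed to tell them apart. Compound 1 and compound 2 carry no numbers, so the steps that involve them cannot be read.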